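The source may hold more compounds than are shown below. What is called first, only, known or untested is meant among the compounds shown, and "the series" means these compounds.

Measured so far:
- compound 1, `O=C(CSc1nc(Nc2ccccc2)c2ccccc2n1)Nc1ccc(F)cc1`, with 34100 nM
- compound 2, `C=CC(=O)Nc1cccc(NC(=O)CSc2nc(Nc3ccccc3Cl)c3ccccc3n2)c1`, with 12700 nM

Both numbers come from a functional assay on MDA-MB-231 cells (Homo sapiens) for inhibition, read by MTT assay, with a stated time of 72 h; on this read-out lower numbers stand for stronger inhibition and higher numbers for weaker inhibition. Among the compounds with values here, compound 2 shows the lowest of the two numbers; the only neighbour is compound 1, whose number is higher by a gap that is beyond the usual scatter, so on this pair compound 2 is the more potent one. Within the data shown here, nothing else has been measured, and no single-change step between two measured compounds exists, so the size of any one substitution is not yet known.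

The next compound is compound 3, `C=CC(=O)Nc1cccc(NC(=O)CSc2nc(Nc3ccc(Br)cc3)c3ccccc3n2)c1`. It differs from compound 2 in one place: 4-bromophenyl in place of 2-chlorophenyl on a nitrogen on an aromatic ring. The rest of the molecule, including the acrylamide-bearing portion shared with compound 2, stays the same.

Among the measured compounds shown here, with no measured step to lean on, the expectation for this assay is a change from compound 2 to compound 3 of a 1.0-fold higher number from compound 2 to compound 3 (0.01 log units; within the scatter), which is no more than the scatter itself and without a firm direction. Compound 3 is therefore estimated at 13000 nM, within a range of 5000 nM to 35000 nM.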

Compound 3, half-maximal inhibitory concentration: 17300 nM
Estimate against measurement, compound 3: 1.3-fold (0.12 log units) below; the measured number falls inside the stated range.
By their numbers in this assay, from the lowest: compounds 2, 3 and 1 (each within the scatter of the next, the first and the last beyond it).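

In this assay, the group on the nitrogen now has its first readable step: 4-bromophenyl in place of 2-chlorophenyl gives a 1.4-fold higher number from compound 2 to compound 3 (0.13 log units; within the scatter), so the read-out does not tell these two groups apart. With the acrylamide-bearing portion held constant, this position therefore accepts either halogen-bearing phenyl group without a resolved difference in this cell assay. The step exchanges the halogen and its ring numbering together, so neither part of the change can be read alone, and no other measurement bears on the result.

The compounds shown leave open how the read-out responds to the two parts of this exchange taken one at a time, which 4-chlorophenyl or 2-bromophenyl on the same nitrogen, each with the same acrylamide-bearing portion, would separate. They also leave open whether a more different group at this position, such as plain phenyl, a phenyl ring carrying a methoxy group or a carboxylic acid, or a saturated ring such as cyclohexyl, would move the number beyond the scatter.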